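Adding a second methoxy to compound 2

This account rests on a few compounds, and the source may have more. Where it says the series, first, only, none or still open, it means among the compounds named here.

Values measured so far in a functional assay on HCT-116 cells (Homo sapiens) for antiproliferative activity, read by MTT assay, with a stated time of 72 h (on this read-out lower numbers stand for stronger inhibition and higher numbers for weaker inhibition), are these.

Compound 1 `COc1cc(OC)cc(-c2cccc(NC(=O)CCc3ccc4c(c3)COB4O)c2)c1` gives 56000 nM
Compound 2 `COc1cccc(-c2cccc(NC(=O)CCc3cccc4c3COB4O)c2)c1` gives 46000 nM

Compound 2 stands at 46000 nM and compound 1 at 56000 nM on this scale. The two values lie within the scatter of each other, so the numbers do not separate them.

The next compound, compound 3 `COc1cc(OC)cc(-c2cccc(NC(=O)CCc3cccc4c3COB4O)c2)c1`, matches compound 2 except in one place. The change is methoxy in place of hydrogen on an aromatic carbon in compound 2, with methoxy in place of hydrogen on an aromatic carbon, which turns 3-methoxyphenyl into 3,5-dimethoxyphenyl.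

For the measured compounds named here, no measured pair shows this change on its own. The closest evidence is compound 1, which already carries 3,5-dimethoxyphenyl on a differently arranged core and gives 56000 nM within the scatter of compound 2. In this assay no step beyond the scatter is therefore expected, in either direction. The estimated step is a 1.0-fold higher number from compound 2 to compound 3 (0.02 log units; within the scatter) and is expected to stay small. For compound 3 the estimated value is 48000 nM with an expected range from 22000 nM to 95000 nM across repeat measurements.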

Compound 3, half-maximal inhibitory concentration: 50000 nM
The estimate for compound 3 lay 1.0-fold (0.02 log units) below the measured number; low and high end bracket the measured number.
By their numbers in this assay, from the lowest: compounds 2, 3 and 1 (each within the scatter of the next).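

In this assay, for the compounds shown here, compound 2 and compound 3 form the first direct pair for this change, which turns 3-methoxyphenyl into 3,5-dimethoxyphenyl: the data show a 1.1-fold higher number from compound 2 to compound 3 (0.04 log units; within the scatter) for methoxy in place of hydrogen on this aromatic carbon, so the numbers do not separate the two compounds. Going by these compounds alone, compound 3 also gives the first comparison of the two differently arranged cores with 3,5-dimethoxyphenyl held constant, and a 1.1-fold lower number from compound 1 to compound 3 (0.05 log units; within the scatter) shows that this rearrangement does not separate the compounds on this read-out either. No measurement shown here accounts for either result.

These compounds leave open whether a different group at this aromatic carbon, such as an amine or a carboxylic acid, would give a step beyond the scatter. They also leave open whether a longer chain on the amide carbonyl would shift the number, since every compound here carries the same chain and the comparisons cover only the two changes above.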